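The compounds below may be only part of what the source reports. "The series", "measured", "known", "first", "only" and "open" are said of these compounds alone.

Compound 1 `O=C(Nc1ccc(C(F)(F)F)cc1)N1CCN(c2nccc(NCc3ccccc3)n2)CC1` gives 2450 nM in a functional assay on MDA-MB-231 cells (Homo sapiens) for antiproliferative activity, read by MTT assay, with a stated time of 24 h; a lower number here means a stronger inhibitor, a higher number a weaker inhibitor. Compound 2 `O=C(Nc1ccccc1Cl)N1CCN(c2nccc(NCc3ccccc3)n2)CC1` carries 2-chlorophenyl in place of 4-(trifluoromethyl)phenyl on an amide-type nitrogen; in this assay compound 2 gives 1590 nM, a step of a 1.5-fold lower number from compound 1 to compound 2 (0.19 log units; within the scatter). Compound 3 `COc1cccc(Nc2ccnc(N3CCN(C(=O)Nc4ccc(C(F)(F)F)cc4)CC3)n2)c1` differs from compound 1 in its core by 3-methoxyphenyl in place of benzyl on a nitrogen on an aromatic ring; in this assay compound 3 gives 1240 nM, a step of a 2.0-fold lower number from compound 1 to compound 3 (0.30 log units; within the scatter). Compound 4 `COc1cccc(Nc2ccnc(N3CCN(C(=O)Nc4ccccc4Cl)CC3)n2)c1` has not been measured; it differs from compound 3 by 2-chlorophenyl in place of 4-(trifluoromethyl)phenyl on an amide-type nitrogen, the same change as between compound 1 and compound 2, at the same place with the same neighbours. For the measured compounds named here, for compound 4 the expected step is a 1.5-fold lower number from compound 3 to compound 4 (0.16 log units; within the scatter), resting on the single prior example of a 1.5-fold lower number from compound 1 to compound 2 (0.19 log units; within the scatter), which stayed within the scatter, so no larger shift is expected here. The estimate for compound 4 in this assay is 850 nM, between 400 nM and 1800 nM.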

Compound 4, half-maximal inhibitory concentration: 5260 nM
Compound 4: the middle estimate sits 6.2-fold (0.79 log units) below what was measured; measured number outside the range, above it.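

In this assay, 2-chlorophenyl in place of 4-(trifluoromethyl)phenyl on an amide-type nitrogen gives a 4.2-fold higher number from compound 3 to compound 4 (0.63 log units; beyond the scatter), which does not match the earlier step on the core of compound 1: the same change on two cores in this assay, a 1.5-fold lower number (0.19 log units; within the scatter) from compound 1 to compound 2 and a 4.2-fold higher number (0.63 log units; beyond the scatter) from compound 3 to compound 4, 6.5-fold (0.82 log units) apart, beyond the scatter of two such steps

Read the other way, 3-methoxyphenyl in place of benzyl on a nitrogen on an aromatic ring gives a 3.3-fold higher number from compound 2 to compound 4 (0.52 log units; beyond the scatter), which also departs from its earlier step: the same change on two cores in this assay, a 2.0-fold lower number (0.30 log units; within the scatter) from compound 1 to compound 3 and a 3.3-fold higher number (0.52 log units; beyond the scatter) from compound 2 to compound 4, 6.5-fold (0.82 log units) apart, beyond the scatter of two such steps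

Across these four compounds, the two changes therefore do not add up and neither step can be carried safely to the other core, but this single set of four shows neither why nor how general the mismatch is.

On these data alone, it remains open whether the mismatch also appears with other groups on the amide-type nitrogen, such as an unsubstituted phenyl or a phenyl bearing a nitrile. Also open, as far as these compounds go, is whether it extends to other groups in place of benzyl and 3-methoxyphenyl, such as a longer chain.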